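Methoxy in place of chloro: compound 3 to compound 4

A few compounds are considered here, and "the series" means these few. Any claim that something is new, unique, unknown or untested is made for them only; others in the source may bear on it.

Three compounds have numbers in an in vitro assay on SH-SY5Y cells for displacement of a labelled ligand from Neuronal acetylcholine receptor; alpha3/beta4 (Homo sapiens); a lower number here means a stronger inhibitor, a higher number a weaker inhibitor. Compound 1 `COc1cncc(C2=CC3CC(C2)CN(C)C3)c1` gives 596 nM. Compound 2 `Clc1ccccc1Oc1cncc(C2=CC3CNCC(C2)C3)c1` gives 26 nM. Compound 3 `Clc1cncc(C2=CC3CNCC(C2)C3)c1` gives 40 nM. Compound 3 stands second highest of the three; its nearest neighbour is compound 2, a gap that lies within the scatter, so no order between the two can be read. Its furthest neighbour is compound 1, a gap well beyond the scatter, and here compound 3 is clearly the stronger of the pair.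

Compound 4 `COc1cncc(C2=CC3CNCC(C2)C3)c1` has not been measured in this assay. It differs from compound 3 in one place: methoxy in place of chloro on an aromatic carbon. Within the data shown here, no pair of measured compounds shows this change on its own, so the step cannot be read off directly. Among the measured compounds shown here, the only compound carrying a methoxy on that ring, compound 1, also carries a methyl on the core nitrogen and gives 596 nM, so it does not separate the two changes.

The expectation is a moderate step towards a higher number, because compound 1 with methoxy gives 596 nM where compound 3 with chloro gives 40 nM; the estimated step from compound 3 to compound 4 is a 2.8-fold higher number from compound 3 to compound 4 (0.44 log units; beyond the scatter). Compound 4 is estimated at 110 nM, with a range from 35 nM to 400 nM.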

Compound 4, inhibition constant: 14.3 nM
For compound 4 the middle estimate is 7.7-fold (0.89 log units) above the measured one, and the stated range ends above it.
By their numbers in this assay, from the lowest: compounds 4, 2 and 3 (each within the scatter of the next, the first and the last beyond it); then compound 1.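

Methoxy in place of chloro on this aromatic carbon, two atoms from the ring nitrogen, gives a gain in this assay, a 2.8-fold lower number from compound 3 to compound 4 (0.45 log units; beyond the scatter), and compound 1 no longer speaks against methoxy, as the large step on the amine nitrogen, a 42-fold lower number from compound 1 to compound 4 (1.62 log units; beyond the scatter), now separates the effect of the methyl there from that of the methoxy. On the oxygen, methyl in place of 2-chlorophenyl gives a 1.8-fold lower number from compound 2 to compound 4 (0.26 log units; within the scatter), within the scatter, so no order can be read between compound 2 and compound 4, and the two groups on that oxygen are not told apart by this assay. No measurement available here accounts for any of these steps.

The compounds shown leave open how an amine or a nitrile on this aromatic carbon would compare with methoxy and chloro, and whether a longer chain on the oxygen, such as ethoxy, would stay level with methyl and 2-chlorophenyl. As far as these compounds go, it also remains open whether an ethyl on the amine nitrogen would behave as the methyl does in compound 1.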